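Swapping Chloro for Fluoro on the Sulfonyl Ring

This account rests on a few compounds, and the source may have more. Where it says the series, first, only, none or still open, it means among the compounds named here.

Compound 1, `CCOC(=O)c1oc2ccc(N(Cc3ccccc3)S(=O)(=O)c3ccccc3Br)cc2c1C`, in a functional assay on HCT-116 cells (Homo sapiens) for inhibition, read by MTT assay, with a stated time of 72 h (a higher number here means a weaker inhibitor, a lower number a stronger inhibitor), gives > 40000 nM, which is a limit of the assay rather than a number.
Compound 2, `CCOC(=O)c1oc2ccc(N(Cc3ccccc3)S(=O)(=O)c3ccc(Cl)cc3)cc2c1C`, in this assay gives 4860 nM.

Among the measured compounds shown here, compound 2 thus holds the only measured number in this assay. For the measured compounds named here, the single measured step, an at least 8.2-fold lower number from compound 1 to compound 2 (0.91 log units; beyond the scatter), rests on (the limit of > 40000 nM in this assay, at which 1 of the 2 values shown sits), so its true size is not known beyond being at least modest.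

Compound 3, `CCOC(=O)c1oc2ccc(N(Cc3ccccc3)S(=O)(=O)c3ccc(F)cc3)cc2c1C`, differs from compound 2 by fluoro in place of chloro on an aromatic carbon. Going by the values given here, the one measured step changed both the kind of halogen and where it sits on the ring, so it does not bear directly on a swap of one halogen for another at the same place. Among the compounds with values here, with no closer precedent, the expectation is a step from compound 2 to compound 3 that stays within the usual scatter of this assay, or at most a slight weakening, estimated as a 1.4-fold higher number from compound 2 to compound 3 (0.16 log units; within the scatter). Compound 3 is therefore expected to give about 7000 nM, in a range from 2500 nM to 20000 nM.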

Compound 3, half-maximal inhibitory concentration: 5820 nM
The estimate for compound 3 lay 1.2-fold (0.08 log units) above the measured number; the range from low to high includes it.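

In this assay, fluoro and chloro at the same place, on an aromatic carbon para to a large group, cannot be told apart: a 1.2-fold higher number from compound 2 to compound 3 (0.08 log units; within the scatter). Among the compounds shown here, this is the first comparison here in which only the halogen changes while its place stays fixed, and for these two halogens the swap makes no difference that this assay can resolve. The other new step, an at least 6.8-fold lower number from compound 1 to compound 3 (0.83 log units; beyond the scatter), resembles the earlier step to the chloro compound, but its true size stays unknown, as the value of compound 1 is a limit of the assay and not a number: the limit of > 40000 nM in this assay, at which 1 of the 3 values shown sits.

Compound 1 differs from the other two in both its halogen and that halogen's place on the ring, so the compounds shown do not separate these two changes, and bromo at the same place as the chloro and fluoro would be needed to do so. Going by these compounds, it also remains open whether this place accepts anything other than a halogen, such as a methoxy group, an amine or a carboxylic acid.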